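A few compounds are considered here, and "the series" means these few. Any claim that something is new, unique, unknown or untested is made for them only; others in the source may bear on it.

Compound 1 `O=C(/C=C/c1cccc([N+](=O)[O-])c1)c1ccc2ccccc2c1`, 11000 nM; compound 2 `O=C(/C=C/c1cccc(Cl)c1)c1ccc2ccccc2c1`, 12000 nM.

In a functional assay on CCRF-CEM cells (Homo sapiens) for cytotoxicity, read by MTT assay, with a stated time of 48 h (on this read-out higher numbers stand for weaker inhibition and lower numbers for stronger inhibition), compound 2 and compound 1 are separated only by the step of a 1.1-fold higher number from compound 1 to compound 2 (0.04 log units; within the scatter), which is within the scatter, so the pair is not distinguishable on this assay. Compound 3 `O=C(/C=C/c1ccccc1)c1ccc2ccccc2c1` differs from compound 2 by hydrogen in place of chloro on an aromatic carbon. Within the data shown here, the one measured step at this position, a 1.1-fold higher number from compound 1 to compound 2 (0.04 log units; within the scatter), shows that swapping one group for another there left the number essentially unchanged; removing the group altogether is untested. On that basis the step of no change at the digits printed from compound 2 to compound 3 (within the scatter) is expected to stay within the scatter. Compound 3 is estimated at 12000 nM, range 5000 nM to 30000 nM.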

Compound 3, half-maximal inhibitory concentration: 14000 nM
Beside the measured number, compound 3's estimate is 1.2-fold (0.07 log units) below it, and the stated range covers the measured number.
By their numbers in this assay, from the lowest: compounds 1, 2 and 3 (each within the scatter of the next).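

In this assay the position now shows more than a swap of one group for another: removing the group altogether also stays within the scatter (a 1.2-fold higher number from compound 2 to compound 3 (0.07 log units; within the scatter)), and the same holds for the direct comparison with the nitro compound (a 1.3-fold higher number from compound 1 to compound 3 (0.10 log units; within the scatter)). On this read-out, the phenyl of compound 3 cannot be told apart from either substituted ring. Still open, as far as these compounds go, is whether an amine or a carboxylic acid at this carbon would move the number, and whether the flat reading extends to other places on the ring. No supporting evidence bears on this result.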